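The source may hold more compounds than are shown below. What is called first, only, known or untested is meant among the compounds shown, and "the series" means these compounds.

Working notes on the series. Compound 1 `COc1cc(C(=O)c2cn(-c3cccc(N)c3)cc2-c2cccc([N+](=O)[O-])c2)cc(OC)c1OC` serves as the reference point. Compound 2 `COc1cc(C(=O)c2cn(-c3cccc(N)c3)cc2-c2ccc([N+](=O)[O-])cc2)cc(OC)c1OC` differs from compound 1 in that (4-nitrophenyl in place of 3-nitrophenyl on an aromatic carbon). Compound 3 `COc1cc(C(=O)c2cn(-c3ccc(F)cc3)cc2-c2cccc([N+](=O)[O-])c2)cc(OC)c1OC` differs from compound 1 in that (4-fluorophenyl in place of 3-aminophenyl on an aromatic nitrogen); this is also how the core of compound 3 differs from the core of compound 1.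

In a functional assay on MCF7 cells (Homo sapiens) for cytotoxicity, read by MTT assay, with a stated time of 96 h (a lower number here means a stronger inhibitor, a higher number a weaker inhibitor), compound 1 gives 510 nM, compound 2 gives 110 nM, and compound 3 gives 440 nM. The move from compound 1 to compound 2 is a 4.6-fold lower number from compound 1 to compound 2 (0.67 log units; beyond the scatter). The move from compound 1 to compound 3 is a 1.2-fold lower number from compound 1 to compound 3 (0.06 log units; within the scatter), so compound 1 and compound 3 are not separated in this assay.

Compound 4 `COc1cc(C(=O)c2cn(-c3ccc(F)cc3)cc2-c2ccc([N+](=O)[O-])cc2)cc(OC)c1OC` has not yet been measured in this assay. It differs from compound 3 in that (4-nitrophenyl in place of 3-nitrophenyl on an aromatic carbon). This is the same kind of change as that from compound 1 to compound 2, not the same: in compound 1 the place is two ring bonds from the ring atom that bears a 3-aminophenyl group, in compound 3 two ring bonds from the ring atom that bears a 4-fluorophenyl group.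

For compound 4 an expected step of a 4.0-fold lower number from compound 3 to compound 4 (0.60 log units; beyond the scatter) in this assay is set beside the earlier one, since the starting points match, because compound 3 gives 440 nM and compound 1 gives 510 nM. The expectation rests on a single precedent, which limits confidence. Compound 4 is expected to give 110 nM in this assay, with a range from 45 nM to 300 nM.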

Compound 4, half-maximal inhibitory concentration: 240 nM
Compound 4: the middle estimate sits 2.2-fold (0.34 log units) below what was measured; the range from low to high includes it.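

In this assay the exchange of 3-nitrophenyl for 4-nitrophenyl on the core bearing 4-fluorophenyl gives a 1.8-fold lower number from compound 3 to compound 4 (0.26 log units; within the scatter), so this step alone does not separate its two compounds, yet it also cannot be told apart from the same exchange on the core bearing 3-aminophenyl: the same change on two cores in this assay, a 4.6-fold lower number (0.67 log units; beyond the scatter) from compound 1 to compound 2 and a 1.8-fold lower number (0.26 log units; within the scatter) from compound 3 to compound 4, 2.5-fold (0.40 log units) apart, within the scatter of two such steps. The exchange of 3-aminophenyl for 4-fluorophenyl, with 4-nitrophenyl on the aromatic carbon, gives a 2.2-fold higher number from compound 2 to compound 4 (0.34 log units; beyond the scatter), and this step likewise cannot be told apart from the same exchange with 3-nitrophenyl in that place: the same change on two cores in this assay, a 1.2-fold lower number (0.06 log units; within the scatter) from compound 1 to compound 3 and a 2.2-fold higher number (0.34 log units; beyond the scatter) from compound 2 to compound 4, 2.5-fold (0.40 log units) apart, within the scatter of two such steps. Neither change therefore shows a detectable dependence on the core, but two pairs of compounds do not show that the steps are equal in size, the nitrophenyl exchange is beyond the scatter on one core only, and nothing here shows how either change behaves on a third core.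

The compounds shown leave open whether the nitrophenyl exchange holds when the aromatic nitrogen carries a different substituent, such as a plain phenyl or a short alkyl chain. They also leave open how the series responds when an amine or a carboxylic acid stands on that phenyl ring in place of the nitro group.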